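Opening the Pyrrolidin-1-yl Group: An Untested Change

The source may report more compounds than this note shows. Statements on the series, on what has been measured and on what is new or still open speak of the compounds shown alone.

Three measured compounds share one core and differ only in the aryl group carried on a nitrogen. Compound 1 `COc1cc2nc(N3CCC(N4CCCC4)CC3)nc(Nc3ccc(F)c(F)c3)c2cc1OC` in a functional assay for antagonist activity at C-C chemokine receptor type 4 (Homo sapiens), read by GTPgammaS binding (a higher number here means a weaker inhibitor, a lower number a stronger inhibitor), gives 25 nM. Compound 2 `COc1cc2nc(N3CCC(N4CCCC4)CC3)nc(Nc3cccc(Br)c3)c2cc1OC` gives 220 nM in this assay, and compound 3 `COc1cc2nc(N3CCC(N4CCCC4)CC3)nc(Nc3ccc(Cl)cc3)c2cc1OC` gives 24 nM. The steps between them are an 8.8-fold higher number from compound 1 to compound 2 (0.94 log units; beyond the scatter), a 1.0-fold lower number from compound 1 to compound 3 (0.02 log units; within the scatter) and a 9.2-fold lower number from compound 2 to compound 3 (0.96 log units; beyond the scatter). Compound 3 therefore sits alongside compound 1, the two being inseparable within the scatter, while compound 2 is clearly the weakest of the three.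

Compound 4 `COc1cc2nc(N3CCC(N(C)CCCO)CC3)nc(Nc3ccc(Cl)cc3)c2cc1OC` keeps the 4-chlorophenyl of compound 3 and changes the other end of the molecule instead: (3-hydroxypropyl)(methyl)amino in place of pyrrolidin-1-yl on a saturated ring carbon. Going by the values given here, none of the measured steps touches this part of the structure; all three vary only the aryl ring, so they give no direct precedent for the size or direction of this step. What remains is that one basic amine side group is exchanged for another, so a modest step, possibly within the scatter, is the most reasonable expectation. For compound 4 the expected value is 45 nM, with a range from 10 nM to 200 nM. The expected step is accordingly a 1.9-fold higher number from compound 3 to compound 4 (0.27 log units; within the scatter).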

Compound 4, half-maximal inhibitory concentration: 43 nM
Estimate against measurement, compound 4: 1.0-fold (0.02 log units) above; the range from low to high includes it.
By their numbers in this assay, from the lowest: compounds 3, 1 and 4 (each within the scatter of the next); then compound 2.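

Going by these compounds alone, compound 4 gives the first view of the group on the saturated ring carbon, since the earlier compounds differ only in the aryl ring. In this assay, replacing pyrrolidin-1-yl with (3-hydroxypropyl)(methyl)amino gives a 1.8-fold higher number from compound 3 to compound 4 (0.25 log units; within the scatter), so the two compounds cannot be told apart, and with the 4-chlorophenyl group in place, this position accepts an open chain as readily as a closed ring, even one that brings a hydrogen-bond donor absent from pyrrolidin-1-yl. No measurement shown here explains why the exchange leaves the number within the scatter.

The compounds shown leave open whether the same exchange would hold with the 3,4-difluorophenyl or 3-bromophenyl group, because this single pair tests it only with 4-chlorophenyl. They also do not reveal whether the hydroxy group contributes at all, or how far the position can be pushed: a plain propyl chain, a longer chain carrying the hydroxy group, or a carboxylic acid in its place could each give a different answer.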